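Methyl in place of hydrogen on compound 2

A few compounds are considered here, and "the series" means these few. Any claim that something is new, unique, unknown or untested is made for them only; others in the source may bear on it.

In an ADME assay on microsomes from liver (Homo sapiens) for metabolic stability (on this read-out lower numbers stand for a shorter-lived compound and higher numbers for a longer-lived compound), compound 1 `O=C1COc2cc(Nc3cc4c(cn3)ncn4CC3CC3)ccc2N1` gives > 1.66 h, which is a limit of the assay and not a number. Within the data shown here, compound 2 `CN1C(=O)COc2cc(Nc3ccc4ncn(CC5CC5)c4n3)cnc21` gives 0.233 h, the only actual number so far. Compound 3 `Cc1cc(Nc2cnc3c(c2)OCC(=O)N3C)nc2c1ncn2CC1CC1` has methyl in place of hydrogen on an aromatic carbon. Among the measured compounds shown here, no measured step isolates this change, so only a small change is expected. The expected step of a 1.1-fold lower number from compound 2 to compound 3 (0.02 log units; within the scatter) in this assay stays within the scatter, with no clear direction. For compound 3 the estimate is 0.22 h, with an expected range from 0.09 h to 0.55 h.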

Compound 3, half-life: 0.483 h
Compound 3: the middle estimate sits 2.2-fold (0.34 log units) below what was measured, and the stated range covers the measured number.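

Methyl in place of hydrogen on the aromatic carbon opposite the ring nitrogen gives a 2.1-fold higher number from compound 2 to compound 3 (0.32 log units; beyond the scatter) in this assay and is the first measured step of the series. The position is therefore not silent: one added carbon moves the half-life modestly upward, beyond the scatter. The earlier compounds shown here, which shared no single-place step, could not show this.

Going by these compounds, whether ethyl, an amine or a longer chain on this carbon would go further stays open. Compound 1 carries a limit and not a number: the limit of > 1.66 h in this assay, at which 1 of the 3 values shown sits.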